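Trading a Nitro Group for Hydroxy and Bromine

This account rests on a few compounds, and the source may have more. Where it says the series, first, only, none or still open, it means among the compounds named here.

Three compounds share one core and differ only in the group on the carbon with a double bond to nitrogen. In a functional assay on BGC-823 cells (Homo sapiens) for cytotoxicity, read by MTT assay, with a stated time of 48 h (a higher number here means a weaker inhibitor, a lower number a stronger inhibitor), compound 1 `O=C(CSc1nnc(-c2ccncc2)o1)N/N=C/c1ccc(O)cc1` gives 7940 nM, compound 2 `Cc1ccc(/C=N/NC(=O)CSc2nnc(-c3ccncc3)o2)cc1` gives 21800 nM, and compound 3 `O=C(CSc1nnc(-c2ccncc2)o1)N/N=C/c1ccccc1[N+](=O)[O-]` gives 41600 nM, the highest of the three numbers. The step of a 5.2-fold higher number from compound 1 to compound 3 (0.72 log units; beyond the scatter) lies beyond the scatter, whereas a 1.9-fold higher number from compound 2 to compound 3 (0.28 log units; within the scatter) does not. Compound 4 `O=C(CSc1nnc(-c2ccncc2)o1)N/N=C/c1cc(Br)ccc1O` carries 5-bromo-2-hydroxyphenyl in place of 2-nitrophenyl on a carbon with a double bond to nitrogen. Since a hydroxy group returns, a lower number is expected for compound 4, roughly a 3.8-fold lower number from compound 3 to compound 4 (0.58 log units; beyond the scatter), because of the step of a 5.2-fold higher number from compound 1 to compound 3 (0.72 log units; beyond the scatter) read in reverse, tempered by the added bromine, for which no comparison exists. The estimate for compound 4 in this assay is 11000 nM, ranging from 4000 nM to 28000 nM.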

Compound 4, half-maximal inhibitory concentration: 9590 nM
The estimate for compound 4 lay 1.1-fold (0.06 log units) above the measured number; the measured number falls inside the stated range.
By their numbers in this assay, from the lowest: compounds 1 and 4 (each within the scatter of the next); then compounds 2 and 3 (each within the scatter of the next).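

In this assay the 5-bromo-2-hydroxyphenyl group gives a 4.3-fold lower number from compound 3 to compound 4 (0.64 log units; beyond the scatter) and also a 2.3-fold lower number from compound 2 to compound 4 (0.36 log units; beyond the scatter), so this position accepts a ring carrying bromine while the number stays clear of those of both compounds. Against the other hydroxy-bearing ring the result is a 1.2-fold higher number from compound 1 to compound 4 (0.08 log units; within the scatter), which leaves these two compounds indistinguishable here although only one carries bromine. Nothing measured here gives a reason for these steps. Still open, on these data alone, is whether the hydroxy group alone or the bromine alone would give the same number. Also open, as far as these compounds go, is what an amine or a carboxylic acid on this ring would do.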